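Two-Methylcyclohexyl in Place of Butyl on the Amide Nitrogen

This account rests on a few compounds, and the source may have more. Where it says the series, first, only, none or still open, it means among the compounds named here.

Compound 1 `CCCCNC(=O)[C@H]1OC(n2cnc3c(N)ncnc32)[C@H](O)[C@@H]1O` is measured in an assay on cell membranes for binding affinity to 2-oxoglutarate receptor 1 (Rattus norvegicus), read by radioligand binding (a lower number here means a stronger inhibitor, a higher number a weaker inhibitor), where compound 1 gives 17 nM. Among the three measured compounds it stands second highest: compound 3 `C[C@H]1CC[C@H](NC(=O)[C@H]2O[C@@H](n3cnc4c(N)ncnc43)[C@H](O)[C@@H]2O)CC1`, which gives 12.9 nM, sits within the scatter of compound 1, while compound 2 `Nc1ncnc2c1ncn2[C@@H]1O[C@H](C(=O)NC2CCCC2)[C@@H](O)[C@H]1O`, with 49 nM, lies beyond the scatter on the weaker side. Compound 4 `CC1CCCCC1NC(=O)[C@H]1OC(n2cnc3c(N)ncnc32)[C@H](O)[C@@H]1O` is not yet measured in this assay. It differs from compound 1 in one place: 2-methylcyclohexyl in place of butyl on an amide-type nitrogen. Among the compounds with values here, only one measured step bears on this change. a 3.8-fold lower number from compound 2 to compound 3 (0.58 log units; beyond the scatter) shows that replacing cyclopentyl with 4-methylcyclohexyl on the amide-type nitrogen gave a clearly stronger compound, and compound 3 is in turn not separable from compound 1 within the scatter. Within the data shown here, the present change also places a methylcyclohexyl group on the amide-type nitrogen, though as 2-methylcyclohexyl rather than the 4-methylcyclohexyl of compound 3, and no measured pair shows what that difference does. The step from butyl to a methyl-bearing ring is therefore expected to be small, and the expected step of a 1.1-fold lower number from compound 1 to compound 4 (0.05 log units; within the scatter) stays within the scatter. Compound 4 is estimated at 15 nM, with a range from 5 nM to 45 nM.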

Compound 4, inhibition constant: 69.5 nM
For compound 4 the middle estimate is 4.6-fold (0.67 log units) below the measured one; the whole stated range lies below it.
By their numbers in this assay, from the lowest: compounds 3 and 1 (each within the scatter of the next); then compounds 2 and 4 (each within the scatter of the next).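

In this assay, a move from butyl to a methyl-bearing cyclohexyl ring on the amide-type nitrogen proved not to be neutral, with a 4.1-fold higher number from compound 1 to compound 4 (0.61 log units; beyond the scatter). A methyl-bearing cyclohexyl ring on this nitrogen therefore does not by itself fix the outcome: compound 3, with 4-methylcyclohexyl, gives 12.9 nM, whereas compound 4, with 2-methylcyclohexyl, gives 69.5 nM, so the place of the methyl on the ring may matter, although compound 4 and compound 3 are not a listed pair and their stereochemistry is not drawn alike. No supporting observation is available to account for this result.

The compounds shown leave open whether the higher number of compound 4 goes with the ring itself or with the methyl on it, a question that plain cyclohexyl on the same nitrogen would address. They also leave open how 3-methylcyclohexyl would compare, and whether the separate stereoisomers of 2-methylcyclohexyl would give the same number in this assay.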